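This account rests on a few compounds, and the source may have more. Where it says the series, first, only, none or still open, it means among the compounds named here.

In an ADME assay on BHK cells (Mesocricetus auratus) for cytotoxicity, read by MTT assay, with a stated time of 96 h (a lower number here means that less compound is tolerated, a higher number that more compound is tolerated), compound 1 `CN1CCN(CC(=O)Nc2ccc(-c3nc4cc(C(F)(F)F)ccc4n3C)cc2)CC1` gives 16000 nM, and compound 3 `O=C(CN1CCCC1)Nc1ccc(-c2nc3ccccc3[nH]2)cc1` gives 55000 nM. For compound 2 `O=C(O)CCC(=O)Nc1ccc(-c2nc3cc(C(F)(F)F)ccc3[nH]2)cc1` the same measurement reaches only a limit of the assay, > 100000 nM, so no number is known for it; it stands at the limit of > 100000 nM in this assay, at which 1 of the 3 values shown sits. Compound 4 `CCN(CC)CC(=O)Nc1ccc(-c2nc3cc(C(F)(F)F)ccc3[nH]2)cc1` differs from compound 2 in one place: diethylamino in place of carboxymethyl on a saturated chain carbon bound to a carbonyl carbon. Going by the values given here, no step between two measured compounds is available, so the size of this change has to be estimated from the rest of the set. Compound 1 with 16000 nM and compound 3 with 55000 nM show that measurable values do occur here. The change is expected to bring compound 4 down from the limit, a step of an at least 3.3-fold lower number from compound 2 to compound 4 (0.52 log units; beyond the scatter). The estimate for compound 4 is 30000 nM, with a range from 8000 nM to 100000 nM.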

Compound 4, half-maximal cytotoxic concentration: 23000 nM
Compound 4: middle estimate off by 1.3-fold (0.12 log units), on the high side; low and high end bracket the measured number.
By their numbers in this assay, from the lowest: compounds 1 and 4 (each within the scatter of the next); then compound 3. At a limit, above all of these: compound 2.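

In this assay, going by these compounds alone, putting diethylamino in place of carboxymethyl on a saturated chain carbon bound to a carbonyl carbon gives an at least 4.3-fold lower number from compound 2 to compound 4 (0.63 log units; beyond the scatter), the only one-place step in this set. It shows that a change at this position can move the tolerated concentration beyond the usual scatter. The step remains a lower bound, because compound 2 gives a limit of the assay rather than a number: the limit of > 100000 nM in this assay, at which 1 of the 4 values shown sits.

Whether the added amine or the lost carboxylic acid accounts for the step remains open. Also open, as far as these compounds go, is whether dimethylamino or morpholine on the same carbon would give a similar number.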